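This account rests on a few compounds, and the source may have more. Where it says the series, first, only, none or still open, it means among the compounds named here.

Compound 1 `CC(C)c1cccc(NC(=O)CCc2cccc3c2B(O)OC3)c1` gives 510 nM
Compound 2 `O=C(CCc1cccc2c1B(O)OC2)Nc1cccc(-c2ccccc2)c1` gives 250 nM
Compound 3 `CSc1cccc(-c2cccc(NC(=O)CCc3cccc4c3B(O)OC4)c2)c1` gives 150 nM

These three values come from a functional assay on SK-OV-3 cells (Homo sapiens) for antiproliferative activity, read by MTT assay, with a stated time of 72 h; a lower number here means a stronger inhibitor, a higher number a weaker inhibitor. At 150 nM, compound 3 sits at the low, more potent end of this small set, but it cannot be separated from compound 2: the measured change is a 1.7-fold lower number from compound 2 to compound 3 (0.22 log units; within the scatter). It is clearly ahead of compound 1, with a 3.4-fold lower number from compound 1 to compound 3 (0.53 log units; beyond the scatter).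

Compound 4 `O=C(CCc1cccc2c1B(O)OC2)Nc1cccc(-c2ccc(C(F)(F)F)cc2)c1` keeps the shared core and changes one group: 4-(trifluoromethyl)phenyl in place of 3-(methylsulfanyl)phenyl on an aromatic carbon. In words, this places 4-(trifluoromethyl)phenyl in place of 3-(methylsulfanyl)phenyl on an aromatic carbon. The phenyl ring stays, and only its substituent differs. For the measured compounds named here, the closest precedent is the addition of methylsulfanyl to compound 2, which gave a 1.7-fold lower number from compound 2 to compound 3 (0.22 log units; within the scatter). The larger change, a 2.0-fold lower number from compound 1 to compound 2 (0.31 log units; beyond the scatter), replaced isopropyl with a ring and is a less direct guide. Neither step tests a trifluoromethyl group, so confidence is limited. The expected change is a 1.3-fold higher number from compound 3 to compound 4 (0.12 log units; within the scatter), which means no shift beyond the scatter is anticipated. For compound 4, the estimated value is 200 nM, with an expected range from 80 nM to 500 nM.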

Compound 4, half-maximal inhibitory concentration: 500 nM
For compound 4 the middle estimate is 2.5-fold (0.40 log units) below the measured one, and the stated range covers the measured number.
By their numbers in this assay, from the lowest: compounds 3, 2, 4 and 1 (each within the scatter of the next, the first and the last beyond it).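

In this assay, for the compounds shown here, the change from 3-(methylsulfanyl)phenyl to 4-(trifluoromethyl)phenyl gives the first step at this position that raises the number beyond the scatter, a 3.3-fold higher number from compound 3 to compound 4 (0.52 log units; beyond the scatter). Yet the other two steps do not separate the compounds: a 2.0-fold higher number from compound 2 to compound 4 (0.30 log units; within the scatter) and a 1.0-fold lower number from compound 1 to compound 4 (0.01 log units; within the scatter), so an added aromatic ring at this position does not by itself guarantee a number lower than that of the isopropyl compound, and what the ring carries can matter. No measurement shown here explains this difference.

This swap changes both the group and its place on the ring, so the two effects cannot be pulled apart; 3-(trifluoromethyl)phenyl and 4-(methylsulfanyl)phenyl would separate them. Also open, on these data alone, is how a phenyl ring carrying an amine or a carboxylic acid would behave here.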